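Working notes on cytotoxicity: compound 4

The compounds below may be only part of what the source reports. "The series", "measured", "known", "first", "only" and "open" are said of these compounds alone.

Measured so far in an ADME assay on HEK293 cells (Homo sapiens) for cytotoxicity, with a stated time of 72 h; on this read-out higher numbers stand for an effect only at larger amounts of compound and lower numbers for an effect already at smaller amounts:
Compound 1 `O=C(Nc1cc(-c2nc3ccccc3s2)ccc1Cl)c1cc([N+](=O)[O-])ccc1Cl` gives > 25000 nM, a limit of the assay.
Compound 2 `COc1ccc(-c2nc3ccccc3s2)cc1NC(=O)c1cc([N+](=O)[O-])ccc1Cl` gives > 25000 nM, a limit of the assay.
Compound 3 `COc1ccc(-c2nc3ccccc3o2)cc1NC(=O)c1cc([N+](=O)[O-])ccc1Cl` gives > 25000 nM, a limit of the assay.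

Compound 2 thus stands only at a limit in this assay, and the two other values shown are limits as well, as summed up by the limit of > 25000 nM in this assay, at which 3 of the 3 values shown sit. The step that the two limits leave unreadable from compound 1 to compound 2, methoxy in place of chloro on an aromatic carbon, cannot be read in size because both ends are limits. The same holds for the step that the two limits leave unreadable from compound 2 to compound 3, 1,3-benzoxazol-2-yl in place of 1,3-benzothiazol-2-yl on an aromatic carbon.

Compound 4 `COc1ccc(-c2nc3ccccc3s2)cc1NC(=O)c1cc([N+](=O)[O-])c(N2CCC(C(=O)O)CC2)cc1Cl` is not yet measured. It differs from compound 2 by 4-carboxypiperidin-1-yl in place of hydrogen on an aromatic carbon. Among the measured compounds shown here, no measured step touches this change, and the two steps that are measured are unreadable, so nothing in the numbers points to a direction. Since every value shown in this assay sits at the limit, compound 4 is expected to stay there too, and the step that the limit leaves unreadable from compound 2 to compound 4 is estimated as none beyond the scatter. For compound 4 the estimate in this assay is 40000 nM, in the range 15000 nM to 120000 nM, most likely reported again as a limit.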

Compound 4, half-maximal effective concentration: > 25000 nM
Compound 4: a limit, no number; the forecaster's own chance of this, stated with the estimate: 85%; the middle value does not contradict the limit.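

In this assay, among the compounds shown here, compound 4 gives > 25000 nM, a limit of the assay, and with compound 2 also at a limit, no step between compound 2 and compound 4 can be read. The series sits at one value: the limit of > 25000 nM in this assay, at which 4 of the 4 values shown sit.

The compounds shown leave open whether any structural change in the series alters cytotoxicity in this assay, and by how much.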